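The source may report more compounds than this note shows. Statements on the series, on what has been measured and on what is new or still open speak of the compounds shown alone.

Compound 1 `O=C(Nc1noc2cnccc12)N1CCN(Cc2cccc(Oc3ccc(Cl)cc3)c2)CC1` and compound 2 `O=C(Nc1noc2cccnc12)N1CCN(Cc2cccc(Oc3ccc(Cl)cc3)c2)CC1` share the same core and differ only in the bicyclic aromatic group sitting on the amide-type nitrogen. Going by the values given here, in an assay on isolated protein for inhibition of Fatty-acid amide hydrolase 1 (Homo sapiens), with a stated time of 60 min (a higher number here means a weaker inhibitor, a lower number a stronger inhibitor), compound 1 gives 0.5 nM, the lowest of the two numbers measured so far, while compound 2 gives 13 nM. Among the compounds with values here, the single measured step, a 26-fold higher number from compound 1 to compound 2 (1.41 log units; beyond the scatter), shows that swapping one bicyclic group for another at this position can move the number a long way. Compound 3 `O=C(Nc1ccc2nccn2c1)N1CCN(Cc2cccc(Oc3ccc(Cl)cc3)c2)CC1` makes a change at exactly the same place: a group of 9 heavy atoms (7 carbon, 2 nitrogen; one five-membered aromatic ring with 2 hetero atoms, one six-membered aromatic ring with 1 hetero atom) in place of a group of 9 heavy atoms (6 carbon, 2 nitrogen, 1 oxygen; one five-membered aromatic ring with 2 hetero atoms, one six-membered aromatic ring with 1 hetero atom), on an amide-type nitrogen. Within the data shown here, no step among the measured compounds involves the entering group itself, so the direction is uncertain, but because a 26-fold higher number from compound 1 to compound 2 (1.41 log units; beyond the scatter) was large and weakening for a comparable swap, a weakening of similar size is expected, estimated as a 40-fold higher number from compound 1 to compound 3 (1.60 log units; beyond the scatter). For compound 3 the expected value in this assay is 20 nM, with a range from 3 nM to 150 nM.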

Compound 3, half-maximal inhibitory concentration: 100 nM
Compound 3: middle estimate off by 5.0-fold (0.70 log units), on the low side, within the range that was stated.
By their numbers in this assay, from the lowest: compound 1; then compound 2; then compound 3.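

The change at this amide-type nitrogen brings a 200-fold higher number from compound 1 to compound 3 (2.30 log units; beyond the scatter), a larger step than the first swap showed, and a 7.7-fold higher number from compound 2 to compound 3 (0.89 log units; beyond the scatter) shows that the two weaker compounds are also clearly apart. All three groups have 9 heavy atoms and the same two aromatic ring types, so these features alone do not fix the number; the entering group has 2 hydrogen-bond acceptors where the group of compound 1 has 3, but the counts printed for the groups of compound 1 and compound 2 match in heavy atoms and ring types, and those compounds still differ widely. Nothing available here explains these differences.

Which feature of these bicyclic groups sets the number remains open. So does whether an amine or a carboxylic acid added to the group of compound 1 would keep the number measured for compound 1, 0.5 nM.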